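Replacing Methylsulfanyl with Hydroxy on the Anilide Ring

The source may hold more compounds than are shown below. What is called first, only, known or untested is meant among the compounds shown, and "the series" means these compounds.

Three amides sharing one core have been measured in an assay on isolated protein for inhibition of phosphodiesterase 4A (Sus scrofa); on this read-out lower numbers stand for stronger inhibition and higher numbers for weaker inhibition. Compound 1 `COc1ccc(C(=O)Nc2ccccc2C)cc1OC1CCCC1` gives 300 nM, compound 2 `COc1ccc(C(=O)Nc2ccccc2F)cc1OC1CCCC1` gives 10700 nM, and compound 3 `COc1ccc(C(=O)Nc2ccccc2SC)cc1OC1CCCC1` gives 1200 nM. Compound 3 therefore holds the second highest number of the three: compound 1 lies nearest, with a 4.0-fold higher number from compound 1 to compound 3 (0.60 log units; beyond the scatter), while compound 2 lies furthest, with an 8.9-fold lower number from compound 2 to compound 3 (0.95 log units; beyond the scatter).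

Compound 4 `COc1ccc(C(=O)Nc2ccccc2O)cc1OC1CCCC1` differs from compound 3 in one place: hydroxy in place of methylsulfanyl on an aromatic carbon. Both measured steps that end at compound 3 bear on this change, since each swaps the group at the same aromatic carbon. Exchanging methyl for methylsulfanyl, from compound 1 to compound 3, was a modest step, and exchanging fluoro for methylsulfanyl, from compound 2 to compound 3, was a larger one in the opposite direction. Among the measured compounds shown here, no measured compound carries a hydroxy group, so the direction for compound 4 rests only on these two neighbours, whose values show that this position tolerates some groups and not others.

Compound 4 is estimated at 3000 nM in this assay, within a range of 600 nM to 15000 nM. The expected step, a 2.5-fold higher number from compound 3 to compound 4 (0.40 log units; beyond the scatter), is a modest weakening with wide uncertainty.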

Compound 4, half-maximal inhibitory concentration: 1300 nM
Estimate against measurement, compound 4: 2.3-fold (0.36 log units) above; low and high end bracket the measured number.
By their numbers in this assay, from the lowest: compound 1; then compounds 3 and 4 (each within the scatter of the next); then compound 2.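

In this assay hydroxy and methylsulfanyl on this aromatic carbon cannot be told apart, with a 1.1-fold higher number from compound 3 to compound 4 (0.03 log units; within the scatter), although hydroxy has fewer heavy atoms and carries a hydrogen-bond donor that methylsulfanyl lacks. Hydroxy stands clear of the other two groups, with an 8.2-fold lower number from compound 2 to compound 4 (0.92 log units; beyond the scatter) against fluoro and a 4.3-fold higher number from compound 1 to compound 4 (0.64 log units; beyond the scatter) against methyl, so at this place, ortho to a large group, the four measured groups fall into three levels: methyl gives the lowest number, fluoro the highest, and methylsulfanyl and hydroxy lie together between them. No evidence is at hand that explains this order or the match between hydroxy and methylsulfanyl.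

The compounds shown leave open whether a methoxy group or an amine on this carbon would join hydroxy and methylsulfanyl at the middle level or come closer to methyl or fluoro. They also leave open whether an ethyl group would keep the low number seen with methyl, and whether the order of these four groups would hold elsewhere on the same aromatic ring.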